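One more methoxy group on compound 2

A few compounds are considered here, and "the series" means these few. Any claim that something is new, unique, unknown or untested is made for them only; others in the source may bear on it.

Compound 1 `COc1cc(O)c(CC=C(C)C)c(O)c1C(=O)/C=C/c1cccc([N+](=O)[O-])c1` gives 16600 nM
Compound 2 `COc1cc(/C=C/C(=O)c2c(OC)cc(OC)cc2OC)cc(OC)c1` gives 9000 nM

In a functional assay on HepG2 cells (Homo sapiens) for inhibition, read by MTT assay, with a stated time of 72 h (on this read-out lower numbers stand for stronger inhibition and higher numbers for weaker inhibition), compound 2 (9000 nM) stands within the scatter of compound 1 (16600 nM). Compound 3 `COc1cc(OC)c(C(=O)/C=C/c2cc(OC)c(OC)c(OC)c2)c(OC)c1` departs from compound 2 in one place, with methoxy in place of hydrogen on an aromatic carbon, ortho to two methoxy groups and para to a large group. Going by the values given here, no measured pair shows this change. In this assay no shift beyond the scatter is expected, and the estimated step of a 1.1-fold lower number from compound 2 to compound 3 (0.05 log units; within the scatter) is small, in either direction. The estimate for compound 3 is 8000 nM (expected range 2500 nM to 25000 nM).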

Compound 3, half-maximal inhibitory concentration: 16500 nM
Compound 3: the middle estimate sits 2.1-fold (0.31 log units) below what was measured; measured number inside the range.
By their numbers in this assay, from the lowest: compounds 2, 3 and 1 (each within the scatter of the next).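

In this assay, a methoxy group in place of hydrogen on this aromatic carbon, ortho to two methoxy groups and para to a large group, gives a 1.8-fold higher number from compound 2 to compound 3 (0.26 log units; within the scatter), so this single pair shows no shift at this position that can be told from the scatter. Nothing at hand offers an account of this outcome. On these data alone, whether an amine, a carboxylic acid or a longer chain on this carbon would move the number beyond the scatter remains open, as does whether a larger alkoxy group would behave as methoxy does.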